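This account rests on a few compounds, and the source may have more. Where it says the series, first, only, none or still open, it means among the compounds named here.

Measured so far:
compound 1, `COc1ccccc1Nc1nc(-c2cccc(F)c2)nc2ccc(F)cc12`: in a functional assay on HT29-AK cells (Homo sapiens) for cytotoxicity, read by MTT assay, with a stated time of 48 h (a lower number here means a stronger inhibitor, a higher number a weaker inhibitor), compound 1 gives > 50000 nM, a limit of the assay.
compound 2, `Fc1ccc(Nc2nc(-c3cccc(F)c3)nc3ccc(F)cc23)cc1`: in this assay compound 2 gives > 50000 nM, a limit of the assay.
compound 3, `Fc1cccc(Nc2nc(-c3cccc(F)c3)nc3ccc(F)cc23)c1`: in this assay compound 3 gives > 50000 nM, a limit of the assay.

Compound 1 thus stands at a limit only; no number places it against the other two. The steps a step that the two limits leave unreadable from compound 1 to compound 2, a step that the two limits leave unreadable from compound 1 to compound 3 and a step that the two limits leave unreadable from compound 2 to compound 3 are all unreadable in size because of the limit of > 50000 nM in this assay, at which 3 of the 3 values shown sit.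

Compound 4, `Fc1cccc(-c2nc(Nc3ccc(Br)cc3)c3cc(F)ccc3n2)c1`, is not yet measured. It differs from compound 1 as follows: 4-bromophenyl in place of 2-methoxyphenyl on a nitrogen on an aromatic ring. The measured steps that exchange the same group, those from compound 1 to compound 2 and from compound 1 to compound 3, give no readable size, so neither a direction nor a magnitude can be taken from them; every exchange of this group so far left the value at the limit. The expectation for compound 4 in this assay is therefore a further value at the limit, estimated at 80000 nM (from 30000 nM to 300000 nM). The step this estimate implies, a step that the limit leaves unreadable from compound 1 to compound 4, is expected to be none beyond the scatter.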

Compound 4, half-maximal inhibitory concentration: > 50000 nM
Compound 4: a limit, no number; the forecaster's own chance of this, stated with the estimate: 80%; the middle value lies beyond the limit too.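

Compound 4 sits at the limit like compound 1, compound 2 and compound 3, so no step among these four compounds can be read: the limit of > 50000 nM in this assay, at which 4 of the 4 values shown sit.

The compounds shown leave open how far each lies beyond the limit, and whether any group on this nitrogen gives a readable value.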